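The source may hold more compounds than are shown below. What is called first, only, known or untested is meant among the compounds shown, and "the series" means these compounds.

The measured compounds in an ADME assay on HEK293 cells (Homo sapiens) for cytotoxicity, read by CCK-8 assay, with a stated time of 48 h; on this read-out lower numbers stand for stronger inhibition and higher numbers for weaker inhibition:
Compound 1, `Cc1nnsc1C(=O)Nc1nc2ccccc2o1`, gives 19600 nM.
Compound 2, `Cc1nnsc1C(=O)Nc1nc2cc(F)ccc2o1`, gives 42000 nM.
Compound 3, `Cc1nnsc1C(=O)Nc1nc2cc(C(C)(C)C)ccc2o1`, gives 6730 nM.

Compound 1 stands second highest of the three numbers: compound 2 lies nearest, with a 2.1-fold higher number from compound 1 to compound 2 (0.33 log units; beyond the scatter), and compound 3 lies furthest, with a 2.9-fold lower number from compound 1 to compound 3 (0.46 log units; beyond the scatter). Between the two substituted analogues the comparison is a 6.2-fold lower number from compound 2 to compound 3 (0.80 log units; beyond the scatter).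

Compound 4, `Cc1nnsc1C(=O)Nc1nc2ccc(C(C)(C)C)cc2o1`, has not yet been measured in this assay. It differs from compound 1 by tert-butyl in place of hydrogen on an aromatic carbon; the tert-butyl sits on an aromatic carbon of the six-membered carbon ring of the fused system, meta to a fused ring and para to a fused ring. The step that bears most directly on this change is a 2.9-fold lower number from compound 1 to compound 3 (0.46 log units; beyond the scatter), where the same group entered the same ring of compound 1, though at a different carbon of it. The comparison a 6.2-fold lower number from compound 2 to compound 3 (0.80 log units; beyond the scatter) points the same way, though it also carries the fluoro exchange. The account therefore expects for compound 4 a modest step to a lower number than compound 1, about a 2.5-fold lower number from compound 1 to compound 4 (0.39 log units; beyond the scatter). Within the data shown here, since the carbon that receives the group is not the one tested in compound 3, some uncertainty remains. Compound 4 is estimated at 8000 nM, with a range from 3500 nM to 18000 nM.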

Compound 4, half-maximal inhibitory concentration: 2420 nM
The estimate for compound 4 lay 3.3-fold (0.52 log units) above the measured number; the whole stated range lies above it.
By their numbers in this assay, from the lowest: compound 4; then compound 3; then compound 1; then compound 2.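

In this assay, tert-butyl in place of hydrogen on the carbon that is meta to a fused ring and para to a fused ring gives an 8.1-fold lower number from compound 1 to compound 4 (0.91 log units; beyond the scatter) and so shows that this carbon also tolerates the group, with the number moving in the same direction as at the carbon tested earlier. The earlier step, a 2.9-fold lower number from compound 1 to compound 3 (0.46 log units; beyond the scatter) for the same group at a different carbon of the same ring, could not show that the choice of carbon goes with the number, whereas the printed values now do: compound 4 gives 2420 nM and compound 3 gives 6730 nM with the same group at that other carbon. Nothing at hand accounts for the difference between the two carbons.

The compounds shown leave open whether the lower number at this carbon is tied to tert-butyl itself or would also follow from a methyl, a methoxy, an amine or a carboxylic acid placed there. They also leave open what fluoro would do on this carbon, since compound 2 carries it on another one.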